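Chloro for methyl on the benzyl group: compound 4

The source may report more compounds than this note shows. Statements on the series, on what has been measured and on what is new or still open speak of the compounds shown alone.

Measured so far:
compound 1 `Cc1ccccc1Cn1cc(COc2ccc3c(=O)ccoc3c2)nn1` gives > 100000 nM
compound 2 `O=c1ccoc2cc(OCc3cn(Cc4cccc(Cl)c4)nn3)ccc12` gives 13700 nM
compound 3 `O=c1ccoc2cc(OCc3cn(Cc4cccc([N+](=O)[O-])c4)nn3)ccc12` gives 9450 nM

In a functional assay on A549 cells (Homo sapiens) for cytotoxicity, read by MTT assay, with a stated time of 48 h (on this read-out lower numbers stand for stronger inhibition and higher numbers for weaker inhibition), compound 1 is reported only as the limit of the assay, > 100000 nM, and no number stands behind it (the limit of > 100000 nM in this assay, at which 1 of the 3 values shown sits). Compound 4 `O=c1ccoc2cc(OCc3cn(Cc4ccccc4Cl)nn3)ccc12` differs from compound 1 by chloro in place of methyl on an aromatic carbon. The measured steps that come closest both start from compound 1 but change the ring substituent and its place at once: an at least 7.2-fold lower number from compound 1 to compound 2 (0.86 log units; beyond the scatter), and an at least 10-fold lower number from compound 1 to compound 3 (1.02 log units; beyond the scatter). Between those two end points, a 1.4-fold lower number from compound 2 to compound 3 (0.16 log units; within the scatter), so the kind of group on the phenyl ring matters little once the methyl is gone. For compound 4 the chloro enters where the methyl stood, so only part of that gain is expected to carry over; the step of an at least 2.5-fold lower number from compound 1 to compound 4 (0.39 log units; beyond the scatter) is the expectation, in this assay downward from the limit but smaller than the steps to compound 2 or compound 3. Compound 4 is estimated at 40000 nM, within a range of 10000 nM to 150000 nM, with a real chance that it again stays at the limit.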

Compound 4, half-maximal inhibitory concentration: > 100000 nM
Compound 4 ended at the assay's limit; the forecaster's own chance of this, stated with the estimate: 40%; at least 2.5-fold (0.39 log units) between middle value and limit.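

Compound 4 is also reported only as a limit, so the step from compound 1 cannot be read, and chloro in place of methyl ortho to a large group does not yield a measured value in this assay. Chloro alone therefore does not carry the activity seen in compound 2, since the change in its place on the ring gives (an at least 7.2-fold higher number from compound 2 to compound 4 (0.86 log units; beyond the scatter)), while the comparison with the nitro compound gives (an at least 10-fold higher number from compound 3 to compound 4 (1.02 log units; beyond the scatter)). Among these four compounds, the two with a group ortho to a large group sit at the limit, and compound 2 and compound 3 have measured values: the limit of > 100000 nM in this assay, at which 2 of the 4 values shown sit.

On these data alone, the true values of compound 1 and compound 4 remain unknown. As far as these compounds go, it also remains open whether an amine or a carboxylic acid ortho to a large group would give a measured value.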